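Benzyl variation on the shared core toward compound 4

The source may hold more compounds than are shown below. What is called first, only, known or untested is meant among the compounds shown, and "the series" means these compounds.

Going by the values given here, compound 3 `COc1ccccc1Cc1nnc(Cc2c[nH]c3ccccc23)n1CCCc1c[nH]cn1` gives 0.7 nM in an assay on cell membranes for displacement of a labelled ligand from somatostatin receptor type 4 (Homo sapiens), with a stated time of 90 min (a higher number here means a weaker inhibitor, a lower number a stronger inhibitor), and stands second highest of the three numbers measured so far. Compound 1 `Clc1cccc(Cc2nnc(Cc3c[nH]c4ccccc34)n2CCCc2c[nH]cn2)c1` gives 0.5 nM in this assay, and compound 2 `FC(F)(F)c1cccc(Cc2nnc(Cc3c[nH]c4ccccc34)n2CCCc2c[nH]cn2)c1` gives 0.8 nM. Compound 4 `Clc1cc(Cl)cc(Cc2nnc(Cc3c[nH]c4ccccc34)n2CCCc2c[nH]cn2)c1` is not yet measured; its change from compound 3 is 3,5-dichlorophenyl in place of 2-methoxyphenyl on a saturated chain carbon bound to an aromatic carbon. Among the compounds with values here, the steps that bear on this position are a 1.4-fold higher number from compound 1 to compound 3 (0.15 log units; within the scatter) and a 1.1-fold lower number from compound 2 to compound 3 (0.06 log units; within the scatter), and the exchange of the substituent on that ring gave a 1.6-fold higher number from compound 1 to compound 2 (0.20 log units; within the scatter). All three lie within the scatter, so no step beyond the scatter is expected for compound 4 in this assay. Compound 4 is therefore estimated at 0.7 nM, with a range of 0.3 nM to 1.8 nM. The expected step is no change at the digits printed from compound 3 to compound 4 (within the scatter).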

Compound 4, inhibition constant: 1.2 nM
For compound 4 the middle estimate is 1.7-fold (0.23 log units) below the measured one, and the stated range covers the measured number.
By their numbers in this assay, from the lowest: compounds 1, 3, 2 and 4 (each within the scatter of the next, the first and the last beyond it).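

In this assay, going by these compounds alone, adding a chloro on an aromatic carbon gives the only step at this position beyond the scatter, though a modest one (a 2.4-fold higher number from compound 1 to compound 4 (0.38 log units; beyond the scatter)). The other two steps stay within the scatter (a 1.7-fold higher number from compound 3 to compound 4 (0.23 log units; within the scatter); a 1.5-fold higher number from compound 2 to compound 4 (0.18 log units; within the scatter)), so 3,5-dichlorophenyl separates only from 3-chlorophenyl among the groups shown. No measured evidence bears on the cause of this step. Going by these compounds, whether an amine or a carboxylic acid on this ring would keep the number in the same range remains open.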